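Branching the amine substituent: compound 2 to compound 3

The source may hold more compounds than are shown below. What is called first, only, known or untested is meant among the compounds shown, and "the series" means these compounds.

Measured so far in a functional assay (ileum) for inhibition, with Cavia porcellus as the target; a higher number here means that more compound is needed for the effect, a lower number that less compound is needed:
compound 1 `CC(C)NC1=NS(=O)(=O)c2cccnc2N1`: > 300 uM, a limit
compound 2 `CC(C)NC1=NS(=O)(=O)c2cc(Cl)cnc2N1`: > 300 uM, a limit

In this assay compound 1 gives only a limit of the assay, > 300 uM. Compound 2 likewise gives only a limit, > 300 uM. The step that the two limits leave unreadable from compound 1 to compound 2 is thus not readable; the limit of > 300 uM in this assay, at which 2 of the 2 values shown sit, is the whole of the evidence. Compound 3 `CC(NC1=NS(=O)(=O)c2cc(Cl)cnc2N1)C(C)(C)C` differs from compound 2 by tert-butyl in place of methyl on a saturated chain carbon bound to an amine nitrogen and a saturated chain carbon. Going by the values given here, no measured step speaks to this change, and compound 2 stands only at the limit. Compound 3 is therefore expected to stay at or near that limit, an estimated step of a number no higher from compound 2 to compound 3 (the limit leaves the size open). The estimate for compound 3 is 300 uM, ranging from 100 uM to 1000 uM.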

Compound 3, concentration for half-maximal effect: > 300 uM
Compound 3: only a limit was reported; the forecaster's own chance of this, stated with the estimate: 75%; the middle value sits exactly at the limit.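

In this assay compound 3 gives > 300 uM, a limit of the assay, and the step from compound 2 to compound 3 cannot be read. The compounds shown leave open whether either change alters the effect at all, the whole record being one limit: the limit of > 300 uM in this assay, at which 3 of the 3 values shown sit.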